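The compounds below may be only part of what the source reports. "The series", "measured", "known", "first", "only" and "open" are said of these compounds alone.

Compound 1 `O=C(c1cnc(NC(=O)C2CCCCC2)s1)c1cccc2ccccc12` and compound 3 `O=C(CCC1CCCCC1)Nc1ncc(C(=O)c2cccc3ccccc23)s1` share a core, and compound 2 `O=C(Nc1ncc(Cc2cccc3ccoc23)s1)C1CCCCC1` carries a different one; the difference between the two cores is not broken down here. In an ADME assay on P388D1 cells (Mus musculus) for cytotoxicity, read by fluorescence and resazurin assay, with a stated time of 72 h (on this read-out higher numbers stand for weaker inhibition and lower numbers for stronger inhibition), compound 1 gives > 40000 nM, which is a limit of the assay and not a number. Compound 3 in this assay likewise gives > 40000 nM, again only a limit. Compound 2 in this assay gives > 40000 nM, also a limit. The change from compound 1 to compound 3 is 2-cyclohexylethyl in place of cyclohexyl on a carbonyl carbon; its step is a step that the two limits leave unreadable from compound 1 to compound 3 because of the limit of > 40000 nM in this assay, at which 3 of the 3 values shown sit.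

Compound 4 `O=C(CCC1CCCCC1)Nc1ncc(Cc2cccc3ccoc23)s1` has not yet been measured. It arises from compound 2 by 2-cyclohexylethyl in place of cyclohexyl on a carbonyl carbon, the same change as from compound 1 to compound 3, made at a place described in identical terms. Since the earlier step left both ends at the limit, compound 4 is expected to behave as compound 2 does, giving an expected step that the limit leaves unreadable from compound 2 to compound 4 in this assay. Compound 4 is thus estimated at 70000 nM in this assay, within 30000 nM to 150000 nM, most likely reported only as a limit.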

Compound 4, half-maximal inhibitory concentration: 17800 nM
For compound 4 the middle estimate is 3.9-fold (0.59 log units) above the measured one; measured number below the stated range.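

In this assay, 2-cyclohexylethyl in place of cyclohexyl on a carbonyl carbon gives an at least 2.2-fold lower number from compound 2 to compound 4 (0.35 log units; beyond the scatter), so on the core of compound 2 the change brings stronger inhibition, by a margin beyond the scatter. Among the compounds shown here, the same change on the core of compound 1 cannot be read, because both of its ends sit at a limit of the assay: the limit of > 40000 nM in this assay, at which 3 of the 4 values shown sit. The single readable step therefore does not show that the change carries from one core to the other, nor that it fails to carry, and its true size remains unknown, since its starting point is only a limit.

The compounds shown leave open whether a chain longer than 2-cyclohexylethyl, or an amine or a carboxylic acid on that chain, would move the number further in this assay. They also leave open whether the lower number would appear on any core other than that of compound 2.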